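Swapping the Ring Substituent on a Kinase-Like Core

A few compounds are considered here, and "the series" means these few. Any claim that something is new, unique, unknown or untested is made for them only; others in the source may bear on it.

Measured compounds:
- compound 1, `O=c1cc(-c2c[nH]c3ncccc23)nc(NC2CCCCC2)[nH]1`: 103 nM
- compound 2, `CN(c1nc(-c2c[nH]c3ncccc23)cc(=O)[nH]1)C1CCCCC1`: 106 nM

Both compounds were tested in a functional assay on HCT-116 cells (Homo sapiens) for cytotoxicity, with a stated time of 3 days; on this read-out higher numbers stand for an effect only at larger amounts of compound and lower numbers for an effect already at smaller amounts. Compound 1 stands at the lower of the two numbers, but compound 2 is so close that the two are indistinguishable: the step of a 1.0-fold higher number from compound 1 to compound 2 (0.01 log units; within the scatter) shows that adding a methyl to the ring nitrogen changes nothing beyond the scatter.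

Compound 3, `COC1CCN(c2nc(-c3c[nH]c4ncccc34)cc(=O)[nH]2)CC1`, has not yet been measured. It differs from compound 1 by 4-methoxypiperidin-1-yl in place of cyclohexylamino on an aromatic carbon. The new group, like the methylated nitrogen in compound 2, carries no hydrogen-bond donor at this position, and the step of a 1.0-fold higher number from compound 1 to compound 2 (0.01 log units; within the scatter) suggests that losing that donor is tolerated. Among the measured compounds shown here, the 4-methoxy group has no counterpart among the measured compounds, so its effect is unknown.

Compound 3 is therefore expected to give 150 nM in this assay, within 50 nM to 500 nM, a step of a 1.5-fold higher number from compound 1 to compound 3 (0.16 log units; within the scatter) that is estimated to stay near the scatter.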

Compound 3, half-maximal effective concentration: 520 nM
The estimate for compound 3 lay 3.5-fold (0.54 log units) below the measured number, outside the stated range (above it).
By their numbers in this assay, from the lowest: compounds 1 and 2 (each within the scatter of the next); then compound 3.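

The group on the aromatic carbon between two ring nitrogen atoms does matter in this assay: the change to 4-methoxypiperidin-1-yl gives a 5.0-fold higher number from compound 1 to compound 3 (0.70 log units; beyond the scatter) and a 4.9-fold higher number from compound 2 to compound 3 (0.69 log units; beyond the scatter) as modest steps. Compound 2 also lacks the hydrogen on that nitrogen yet stays within the scatter of compound 1, so losing this hydrogen-bond donor does not by itself account for the higher number of compound 3. What drives the step must therefore lie elsewhere in the exchange of groups, although nothing measured here explains it.

Compound 3 changes the ring and adds the methoxy group in a single exchange, so their separate contributions remain unresolved. A plain piperidin-1-yl group or a 4-methoxycyclohexylamino group would be needed to tell them apart.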